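The source may hold more compounds than are shown below. What is called first, only, known or untested is meant among the compounds shown, and "the series" means these compounds.

In an ADME assay on cells (Astrocyte, Homo sapiens) for cytotoxicity, read by WST assay, with a stated time of 72 h (on this read-out lower numbers stand for stronger inhibition and higher numbers for weaker inhibition), compound 1 (`O=C(Nc1cc2ncncc2cc1OCc1ccc(F)cc1)Nc1cccc2ccccc12`) gives 8500 nM as its reading. Compound 2 (`O=C(Nc1cc2ncncc2cc1OCc1cccc(F)c1)Nc1cccc2ccccc12`) reads > 10000 nM and this is a limit of the assay, not a number. Compound 2 sits at the limit of > 10000 nM in this assay, at which 1 of the 2 values shown sits, on the numbers shown. Compound 3 (`O=C(Nc1cc2ncncc2cc1OCc1ccccc1Cl)Nc1cccc2ccccc12`) has yet to be measured, and it carries 2-chlorophenyl in place of 3-fluorophenyl on a saturated chain carbon bound to an oxygen on an aromatic ring. Within the data shown here, the only measured step at this same place is an at least 1.1-fold higher number from compound 1 to compound 2 (0.07 log units; that floor lies within the scatter) and it gives no ground to expect a shift beyond the scatter in this assay for the new group. The expected step is an at least 1.1-fold lower number from compound 2 to compound 3 (0.04 log units; that floor lies within the scatter) as an estimate. For compound 3 the estimated value is 9000 nM with an expected range from 4500 nM to 16000 nM for this reading.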

Compound 3, half-maximal inhibitory concentration: 2300 nM
For compound 3 the middle estimate is 3.9-fold (0.59 log units) above the measured one; the whole stated range lies above it.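

In this assay, among these compounds, the floor of the only earlier step at this place lay within the scatter, so the compounds did not yet show that the group here mattered. With 2-chlorophenyl on a saturated chain carbon bound to an oxygen on an aromatic ring, the reading moves beyond the scatter against both fluorinated compounds: an at least 4.3-fold lower number from compound 2 to compound 3 (0.63 log units; beyond the scatter), and a 3.7-fold lower number from compound 1 to compound 3 (0.57 log units; beyond the scatter). The reading of compound 2 is a limit of the assay, not a number: the limit of > 10000 nM in this assay, at which 1 of the 3 values shown sits.

The compounds shown never put fluorine and chlorine at the same place on the ring, and whether the element or its place matters stays open. Also open, on these data alone, is how a plain phenyl group without a halogen, or a phenyl group carrying a methoxy group, would read in this assay.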